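This account rests on a few compounds, and the source may have more. Where it says the series, first, only, none or still open, it means among the compounds named here.

Working notes on the series. Going by the values given here, all members share one core; compound 1 `C=CCn1nc(Cc2ccc(Cl)cc2)c2ccccc2c1=O` is the only member for which a result is known: in a functional assay on aorta with Alpha-1D adrenergic receptor (Rattus norvegicus) as the target (a higher number here means that more compound is needed for the effect, a lower number that less compound is needed), compound 1 gives 2600 nM. Compound 2 `C=CCn1nc(Cc2ccc(OC)cc2)c2ccccc2c1=O` differs from compound 1 in the group on the pendant aromatic ring, and compound 3 `CCn1nc(Cc2ccc(OC)cc2)c2ccccc2c1=O` carries a shorter chain on the ring nitrogen than compound 2. In this assay compound 2 gives "not determined" (no result reported), and in this assay compound 3 gives "not determined" (no result reported), so compound 2 stands on no number of its own, and the series has one measured point only, compound 1.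

The next compound, compound 4 `C=CCn1nc(Cc2ccc(OC)c(OC)c2)c2ccccc2c1=O`, arises from compound 2 by methoxy in place of hydrogen on an aromatic carbon. Among the compounds with values here, no step between two measured compounds is available to calibrate this change, and compound 2, the direct parent, is itself unmeasured; the only anchor is compound 1 at 2600 nM. A step of either direction beyond the usual scatter cannot be ruled out, nor can a step within it, so the range is kept wide. In this assay compound 4 is expected to give about 3000 nM, between 500 nM and 20000 nM, with compound 1 as the reference point for this estimate.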

Compound 4, half-maximal effective concentration: 9800 nM
Compound 4: middle estimate off by 3.3-fold (0.51 log units), on the low side; the measured number falls inside the stated range.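

Going by these compounds alone, compound 2 has no single number in this assay, and the pair of compound 2 and compound 4 therefore gives no step. The compounds shown leave open how methoxy in place of hydrogen shifts the value on this core. Nothing at hand bears on the result of compound 4.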